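Swapping Phenyl for Pyridin-2-yl on the Carbonyl Carbon

A few compounds are considered here, and "the series" means these few. Any claim that something is new, unique, unknown or untested is made for them only; others in the source may bear on it.

Compound 1 `COc1ccc(-c2cc3ccccc3nc2/C=C/C(=O)c2ccccc2)cc1` and compound 2 `COc1ccc(-c2cc3ccccc3nc2/C=C/C(=O)c2ccc(OC)cc2OC)cc1` share one core and differ only in the ring attached to the carbonyl carbon. In a functional assay on A549 cells (Homo sapiens) for antiproliferative activity, read by XTT assay, with a stated time of 72 h (on this read-out higher numbers stand for weaker inhibition and lower numbers for stronger inhibition), compound 1 gives 7410 nM, and in the same this assay compound 2 gives 7990 nM. Within the data shown here, the one step measured so far, a 1.1-fold higher number from compound 1 to compound 2 (0.03 log units; within the scatter), is within the scatter, so the two numbers cannot be told apart; compound 1 simply sits within the scatter of compound 2 on the numbers in hand.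

Compound 3 `COc1ccc(-c2cc3ccccc3nc2/C=C/C(=O)c2ccccn2)cc1` is a fresh variation on compound 1: pyridin-2-yl in place of phenyl on a carbonyl carbon. Among the measured compounds shown here, no measured step exchanges the phenyl itself for a ring holding a nitrogen, so the only guide is the step from compound 1 to compound 2, which changed substituents on that same ring without moving the number beyond the scatter. On that slender basis, the number for compound 3 in this assay is expected to stay close to that of compound 1, with an expected step of a 1.1-fold lower number from compound 1 to compound 3 (0.02 log units; within the scatter). The estimate for compound 3 is therefore 7000 nM, within a range from 2500 nM to 20000 nM.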

Compound 3, half-maximal inhibitory concentration: 6140 nM
Estimate against measurement, compound 3: 1.1-fold (0.06 log units) above; the measured number falls inside the stated range.
By their numbers in this assay, from the lowest: compounds 3, 1 and 2 (each within the scatter of the next).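

Compound 1 and compound 2 differ only in substituents on the ring at this carbonyl carbon, whereas compound 3 changes the ring itself, placing a nitrogen in it and adding one hydrogen-bond acceptor by the count. In this assay this exchange gives a 1.2-fold lower number from compound 1 to compound 3 (0.08 log units; within the scatter) and so does not separate pyridin-2-yl from phenyl on these numbers. The comparison with the substituted ring gives a 1.3-fold lower number from compound 2 to compound 3 (0.11 log units; within the scatter) and, together with the earlier step, shows that phenyl, 2,4-dimethoxyphenyl and pyridin-2-yl on this carbonyl carbon cannot be told apart here, while no measurement available offers an account of this result.

The compounds shown leave open whether the number would also stay put with the ring nitrogen elsewhere, as in pyridin-3-yl or pyridin-4-yl, or with a different ring, such as thiophene, at this carbonyl carbon. They also leave open whether an amine or a carboxylic acid on this ring, or a saturated ring such as cyclohexyl in its place, would produce a step beyond the scatter.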